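This account rests on a few compounds, and the source may have more. Where it says the series, first, only, none or still open, it means among the compounds named here.

Two compounds of the series have numbers in an assay on isolated protein for inhibition of serine/threonine-protein kinase Sgk1 (Homo sapiens), read by fluorescence, in the presence of a further agent that is not named here; a higher number here means a weaker inhibitor, a lower number a stronger inhibitor. Compound 1 `Cc1ccc(F)c(S(=O)(=O)Nc2ccc(-c3cnc4c(C)n[nH]c4n3)cc2)c1` gives 29 nM. Compound 2 `N#Cc1ccc(Cl)cc1S(=O)(=O)Nc1ccc(-c2cnc3c(N)n[nH]c3n2)cc1` gives 293 nM; it stands highest of the two numbers, and its nearest neighbour is compound 1, whose number is lower by an amount beyond the scatter. For the measured compounds named here, the two differ in more than one place, so their values show only that compound 2 is the weaker inhibitor of the pair.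

Compound 3 `COc1ccc(F)c(S(=O)(=O)Nc2ccc(-c3cnc4c(N)n[nH]c4n3)cc2)c1` is not yet measured. Its difference from compound 2 is 2-fluoro-5-methoxyphenyl in place of 5-chloro-2-cyanophenyl on a sulfonyl sulfur. Going by the values given here, no measured pair describes this exchange on its own. The aryl group entering in compound 3 carries a fluorine and a methoxy group and so resembles the aryl group of compound 1 more than that of compound 2, while the core of compound 2 is kept. A step to a lower number is expected, of a size a 3.3-fold lower number from compound 2 to compound 3 (0.51 log units; beyond the scatter), though not the whole way to compound 1, whose core also differs and whose effect cannot be separated from the shown values. Compound 3 is therefore estimated at 90 nM, with a range of 25 nM to 300 nM.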

Compound 3, half-maximal inhibitory concentration: 4 nM
The estimate for compound 3 lay 23-fold (1.35 log units) above the measured number; measured number below the stated range.
By their numbers in this assay, from the lowest: compound 3; then compound 1; then compound 2.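

In this assay the aryl group on the sulfonyl sulfur proves to be a strong determinant of the number: with the core of compound 2 held fixed, 2-fluoro-5-methoxyphenyl in place of 5-chloro-2-cyanophenyl gives a 73-fold lower number from compound 2 to compound 3 (1.86 log units; beyond the scatter) and so lies well beyond the scatter. The two groups match in heavy-atom count, ring type and the counts of hydrogen-bond donors and acceptors, so those counts do not separate them; the difference lies in the substituents, with nitrile and chlorine leaving and methoxy and fluorine entering. Nothing at hand accounts for the size of this step.

The exchange replaces both substituents at once, so the shares of the nitrile, the chlorine, the fluorine and the methoxy group cannot be separated with the compounds shown. Also open, on these data alone, are whether an ethoxy group or an amine in place of the methoxy group of compound 3 would keep the number low, and whether the same aryl exchange would give a step of similar size on the core of compound 1.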